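The source may report more compounds than this note shows. Statements on the series, on what has been measured and on what is new or still open speak of the compounds shown alone.

Measured so far in a functional assay on COLO 205 cells (Homo sapiens) for inhibition, read by sulforhodamine B assay, with a stated time of 48 h; on this read-out lower numbers stand for stronger inhibition of growth and higher numbers for weaker inhibition of growth:
compound 1 `COc1cc2cc(Oc3ccc(NC(=O)Nc4cccc(C(F)(F)F)c4)cc3)c(C)nc2cc1OC` gives 1120 nM;
compound 2 `COc1cc2cc(Oc3ccc(NC(=O)Nc4ccc(Cl)c(C(F)(F)F)c4)cc3)c(C)nc2cc1OC` gives 660 nM.

For the measured compounds named here, compound 2 holds the lowest of these two numbers, but the only step recorded, a 1.7-fold lower number from compound 1 to compound 2 (0.23 log units; within the scatter), lies within the scatter, so the two compounds cannot be ordered. Compound 3 `COc1cc2cc(Oc3ccc(NC(=O)Nc4ccc(Cl)c(Cl)c4)cc3)c(C)nc2cc1OC` differs from compound 2 by chloro in place of trifluoromethyl on an aromatic carbon. Going by the values given here, no measured step exchanges these two groups, so the guidance is loose. Because a 1.7-fold lower number from compound 1 to compound 2 (0.23 log units; within the scatter) stayed within the scatter for a change on this same ring, only a small step is expected here, a 1.4-fold higher number from compound 2 to compound 3 (0.13 log units; within the scatter), with no clear direction. Compound 3 is therefore estimated at 900 nM, ranging from 400 nM to 2000 nM.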

Compound 3, concentration for 50% growth inhibition: 2750 nM
Beside the measured number, compound 3's estimate is 3.1-fold (0.49 log units) below it; measured number outside the range, above it.
By their numbers in this assay, from the lowest: compounds 2 and 1 (each within the scatter of the next); then compound 3.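

Putting chloro in place of trifluoromethyl on this aromatic carbon, ortho to a chloro group, gives a 4.2-fold higher number from compound 2 to compound 3 (0.62 log units; beyond the scatter) and so shows that this position can shift growth inhibition beyond the scatter, which the earlier step on the same ring did not. The wider change from 3-(trifluoromethyl)phenyl to 3,4-dichlorophenyl gives a 2.5-fold higher number from compound 1 to compound 3 (0.39 log units; beyond the scatter) and points the same way, so the second chloro does not make up for the lost trifluoromethyl. No evidence is available to explain these steps. From the compounds shown here alone, how a nitrile or a methoxy group would behave on this same carbon remains open.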